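Compound 3 to compound 4: a larger group on the sulfur chain

The source may report more compounds than this note shows. Statements on the series, on what has been measured and on what is new or still open speak of the compounds shown alone.

Measured in a functional assay on HCT-116 cells (Homo sapiens) for inhibition, read by MTT assay, with a stated time of 48 h (on this read-out higher numbers stand for weaker inhibition and lower numbers for stronger inhibition), each value a limit of the assay:
compound 1 (`COc1ccc(-n2c(SC)nnc2-c2cc(OC)c(OC)c(OC)c2)cc1`): > 60000 nM
compound 2 (`CCOC(=O)CSc1nnc(-c2cc(OC)c(OC)c(OC)c2)n1-c1ccc(OC)cc1`): > 60000 nM
compound 3 (`COc1cc(-c2nnc(SC)n2-c2ccc(N(C)C)cc2)cc(OC)c1OC`): > 60000 nM

Compound 3 gives no number in this assay, only a limit (> 60000 nM). Within the data shown here, it has no company above or below it: the series so far offers (the limit of > 60000 nM in this assay, at which 3 of the 3 values shown sit), and no compound can be ranked.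

Compound 4 (`COc1ccc(CSc2nnc(-c3cc(OC)c(OC)c(OC)c3)n2-c2ccc(N(C)C)cc2)cc1`) carries 4-methoxyphenyl in place of hydrogen on a saturated chain carbon bound to a sulfur, which turns methylsulfanyl into (4-methoxybenzyl)sulfanyl.

Among the measured compounds shown here, two measured steps bear on this. The nearer is a step that the two limits leave unreadable from compound 1 to compound 2 (ethoxycarbonyl in place of hydrogen on the same kind of carbon). The other is a step that the two limits leave unreadable from compound 1 to compound 3 (dimethylamino in place of methoxy on an aromatic carbon). Neither has a size that can be carried over, so the expectation rests on little. Any readable step in this assay would have to run toward stronger inhibition, and a further limit is about as likely.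

The expected step, an estimate only, is an at least 3.0-fold lower number from compound 3 to compound 4 (0.47 log units; beyond the scatter) (toward stronger inhibition, if a number appears at all). The value estimated for compound 4 is 20000 nM (range 500 nM to 60000 nM).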

Compound 4, half-maximal inhibitory concentration: 1150 nM
Compound 4: middle estimate off by 17-fold (1.24 log units), on the high side; the range from low to high includes it.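

In this assay, among these compounds, the saturated chain carbon bound to a sulfur is the first place where a change yields a readable step: 4-methoxyphenyl in place of hydrogen gives an at least 52-fold lower number from compound 3 to compound 4 (1.71 log units; beyond the scatter). Compound 3 is held only as a limit, so this step fixes a minimum size and not an exact one, and compound 4 supplies the first real number against which later changes can be measured. The earlier changes, ethoxycarbonyl on the same kind of carbon and dimethylamino in place of methoxy on an aromatic carbon, cannot be read, and the three earlier compounds offer no ranking: the limit of > 60000 nM in this assay, at which 3 of the 4 values shown sit.

Going by these compounds, it remains open whether the step depends on the aromatic ring, on the methoxy group it carries, or on neither, and a plain benzyl group or a longer alkyl chain on the sulfur would separate these possibilities. On these data alone, it also remains open whether (4-methoxybenzyl)sulfanyl gives a readable number when methoxy stands in place of dimethylamino on the aromatic carbon.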